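A Dioxolane Group in Place of an Oxolane Group

This account rests on a few compounds, and the source may have more. Where it says the series, first, only, none or still open, it means among the compounds named here.

In a functional assay on SH-SY5Y cells (Homo sapiens) for cytotoxicity, read by MTT assay, with a stated time of 72 h (on this read-out higher numbers stand for weaker inhibition and lower numbers for stronger inhibition), compound 2 `O=C1c2c[n+]([O-])c3ccccc3c2C(=O)c2c1c1ccccc1n2Cc1cn([C@H]2O[C@H](CO)[C@@H](O)[C@H]2O)nn1` gives 1340 nM and stands second highest of three numbers. Compound 1 `CN(C)CCCCCn1c2c(c3ccccc31)C(=O)c1c[n+]([O-])c3ccccc3c1C2=O` gives the lowest number at 370 nM and compound 3 `CCCCN1CCN(CCCCn2c3c(c4ccccc42)C(=O)c2c[n+]([O-])c4ccccc4c2C3=O)CC1` the highest at 6100 nM in the same read-out. Compound 4 `CC1(C)O[C@@H](CO)[C@H](Cn2cc(Cn3c4c(c5ccccc53)C(=O)c3c[n+]([O-])c5ccccc5c3C4=O)nn2)O1` differs from compound 2 at one place: (5-(hydroxymethyl)-2,2-dimethyl-1,3-dioxolan-4-yl)methyl in place of 3,4-dihydroxy-5-(hydroxymethyl)oxolan-2-yl on an aromatic nitrogen. Among the measured compounds shown here, the only measured step, a 16-fold higher number from compound 1 to compound 3 (1.22 log units; beyond the scatter), concerns a different group at a different place, so it shows that a side-chain swap can be large but gives no direction here. No step beyond the scatter is therefore expected in this assay. The expected change is a 1.3-fold higher number from compound 2 to compound 4 (0.10 log units; within the scatter) as an estimate. For compound 4 the estimated value is 1700 nM, with an expected range from 550 nM to 5500 nM.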

Compound 4, half-maximal inhibitory concentration: > 1000 nM
Compound 4: a limit, no number; the forecaster's own chance of this, stated with the estimate: 5%; the middle value does not contradict the limit.
By their numbers in this assay, from the lowest: compound 1; then compound 2; then compound 3.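

In this assay, among the compounds shown here, compound 4 gives > 1000 nM, which is a limit and not a number, so no step from compound 2 to compound 4 can be read. The compounds shown leave open whether the number for compound 4 would lie higher or lower than that for compound 2.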